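The source may report more compounds than this note shows. Statements on the series, on what has been measured and on what is new or still open speak of the compounds shown alone.

Compound 1, `COc1ccc(-c2cccc(=O)n2-c2cc(OC)c(OC)c(OC)c2)cc1`, was tested in a functional assay on HepG2 cells (Homo sapiens) for cytotoxicity, read by spectrophotometry, with a stated time of 72 h; on this read-out lower numbers stand for stronger inhibition and higher numbers for weaker inhibition. In this assay compound 1 gives a result reported only as a limit of the assay, < 10 nM. Compound 2, `COc1cc(-n2c(-c3ccc([N+](=O)[O-])cc3)cccc2=O)cc(OC)c1OC`, is compound 1 with nitro in place of methoxy on an aromatic carbon. In this assay compound 2 likewise gives only a limit, < 10 nM. The step that the two limits leave unreadable from compound 1 to compound 2 cannot be sized, due to the limit of < 10 nM in this assay, at which 2 of the 3 values shown sit. Compound 3, `COc1ccc(-n2c(-c3cc(OC)c(OC)c(OC)c3)cccc2=O)cc1`, contains the same atoms as compound 1 joined differently; the difference between the two cores is not broken down here. In this assay, among the measured compounds shown here, compound 3 gives 5740 nM, the only plain number among the three measured compounds. Compound 4, `COc1cc(-c2cccc(=O)n2-c2ccc([N+](=O)[O-])cc2)cc(OC)c1OC`, has not yet been measured. It is compound 3 with nitro in place of methoxy on an aromatic carbon, the same change that turns compound 1 into compound 2, made at a place described in the same words. That earlier change left no readable step, so the expectation for compound 4 rests on compound 3 and its value 5740 nM, taken as the starting point. The step of a 1.6-fold lower number from compound 3 to compound 4 (0.21 log units; within the scatter) is expected to be small, with a wide range allowed on either side. Compound 4 is therefore estimated at 3500 nM, with 600 nM to 15000 nM as the expected range.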

Compound 4, half-maximal inhibitory concentration: 941 nM
The estimate for compound 4 lay 3.7-fold (0.57 log units) above the measured number, and the stated range covers the measured number.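

In this assay, replacing 4-methoxyphenyl with 4-nitrophenyl gives a 6.1-fold lower number from compound 3 to compound 4 (0.79 log units; beyond the scatter), a modest step that lies beyond the usual scatter, so on this core the change goes toward stronger inhibition. The same change on the core of compound 1 cannot be sized because compound 1 and compound 2 are both reported only as limits of the assay, which leaves no second step to set beside the first: the limit of < 10 nM in this assay, at which 2 of the 4 values shown sit. This single readable step therefore shows what the change does on one core, but it does not show that the change carries over to another core with the same size or even the same direction, and it gives no reason for the shift.

The compounds shown have only methoxy or nitro on this aromatic carbon, so it remains open what an amine, a carboxylic acid or a longer chain would do there on either core. Also open, from the compounds shown here alone, is how large the methoxy-to-nitro step is on the core of compound 1, a question that needs plain numbers for both partners rather than limits.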